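The source may hold more compounds than are shown below. What is called first, only, known or untested is meant among the compounds shown, and "the series" means these compounds.

Measured compounds in this series:

compound 1, `COc1ccc(-c2ccc(Cl)c(C(=O)NCC3(O)CCCCCC3)c2)nc1` — in a functional assay on HEK293 cells for antagonist activity at P2X purinoceptor 7 (Homo sapiens) (on this read-out higher numbers stand for weaker inhibition and lower numbers for stronger inhibition), compound 1 gives 213 nM
compound 2, `N#Cc1ccc(-c2ccc(Cl)c(C(=O)NCC3(O)CCCCCC3)c2)nc1` — in this assay compound 2 gives 134 nM

Among the measured compounds shown here, compound 2 holds the lowest of the two numbers so far; its nearest neighbour is compound 1, and the step of a 1.6-fold lower number from compound 1 to compound 2 (0.20 log units; within the scatter) stays within the scatter, so the two cannot be ranked against each other.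

Compound 3, `O=C(NCC1(O)CCCCCC1)c1cc(-c2ccc(Cl)cn2)ccc1Cl`, is not yet measured. It differs from compound 2 in one place: chloro in place of cyano on an aromatic carbon.

For the measured compounds named here, only one measured step touches this position of the pyridine ring, namely a 1.6-fold lower number from compound 1 to compound 2 (0.20 log units; within the scatter). That exchange of one group for another at the same aromatic carbon left the number within the scatter. Going by the values given here, the exchange from cyano to chloro at the same place has no measured precedent here, and the single step at hand gives no ground to expect movement in either direction. The working expectation in this assay is therefore no step beyond the scatter.

Compound 3 is expected to give about 150 nM, with a range from 60 nM to 400 nM. This estimate corresponds to an expected step of a 1.1-fold higher number from compound 2 to compound 3 (0.05 log units; within the scatter).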

Compound 3, half-maximal inhibitory concentration: 56 nM
Beside the measured number, compound 3's estimate is 2.7-fold (0.43 log units) above it, and the stated range ends above it.
By their numbers in this assay, from the lowest: compound 3; then compounds 2 and 1 (each within the scatter of the next).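

In this assay, among the compounds shown here, replacing 5-cyanopyridin-2-yl with 5-chloropyridin-2-yl gives a 2.4-fold lower number from compound 2 to compound 3 (0.38 log units; beyond the scatter), and chloro in place of methoxy at the same aromatic carbon gives a 3.8-fold lower number from compound 1 to compound 3 (0.58 log units; beyond the scatter); these are the first steps at this position that lie beyond the scatter. This carbon, two atoms from the ring nitrogen, therefore does respond to the group it carries, a point the within-scatter pair of compound 1 and compound 2 could not show, and chloro stands apart from both methoxy and cyano while those two remain unranked. Nothing available here bears on what lies behind this difference.

With only three groups shown at this carbon, all on the same core, it remains open whether fluoro, bromo, methyl or trifluoromethyl would match the number given by chloro or move further in either direction. Going by these compounds, it also remains open whether the step to chloro would keep its size if another part of the core were changed, such as the chloro group on the other aromatic ring.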